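This account rests on a few compounds, and the source may have more. Where it says the series, first, only, none or still open, it means among the compounds named here.

Measured in an ADME assay on HepG2 cells (Homo sapiens) for cytotoxicity, read by resazurin assay, with a stated time of 24 h; a lower number here means that less compound is tolerated, a higher number that more compound is tolerated:
compound 1 `O=C(O)c1c(O)cc(Cl)cc1C=Cc1ccc2ccccc2c1`: 25000 nM
compound 2 `O=C(O)c1c(O)cccc1C=Cc1ccc2ccccc2c1`: 71000 nM
compound 3 `O=C(O)c1c(O)cccc1CCc1ccc2ccccc2c1`: > 100000 nM (a limit)

Compound 3 gives a limit and not a number (the limit of > 100000 nM in this assay, at which 1 of the 3 values shown sits). Compound 4 `COc1cc(O)c(C(=O)O)c(CCc2ccc3ccccc3c2)c1` carries methoxy in place of hydrogen on an aromatic carbon, para to a carboxy group (methoxy in place of hydrogen on an aromatic carbon). Among the measured compounds shown here, the one measured step that bears on this is a 2.8-fold higher number from compound 1 to compound 2 (0.45 log units; beyond the scatter), where hydrogen takes the place of chloro on an aromatic carbon. Read in reverse, that step suggests a modest fall in this assay when a group replaces hydrogen, although a reading at the limit remains possible. The expected step is an at least 1.2-fold lower number from compound 3 to compound 4 (0.09 log units; that floor lies within the scatter). For compound 4 the estimated value is 80000 nM, with an expected range from 35000 nM to 150000 nM.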

Compound 4, half-maximal cytotoxic concentration: 71000 nM
Beside the measured number, compound 4's estimate is 1.1-fold (0.05 log units) above it; the measured number falls inside the stated range.
By their numbers in this assay, from the lowest: compound 1; then compounds 2 and 4 (each within the scatter of the next). At a limit, above all of these: compound 3.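

In this assay, methoxy in place of hydrogen on the aromatic carbon para to a carboxy group gives an at least 1.4-fold lower number from compound 3 to compound 4 (0.14 log units; that floor lies within the scatter). Only a floor is available for this step, and it does not establish a real fall at this position. Compound 3 is a limit and not a number: the limit of > 100000 nM in this assay, at which 1 of the 4 values shown sits.

Going by these compounds, the true size of the methoxy step stays open, with no number for compound 3 to set against compound 4. Also open, on these data alone, is how an amine or an ethoxy group on the same aromatic carbon would read.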